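The source may report more compounds than this note shows. Statements on the series, on what has been measured and on what is new or still open speak of the compounds shown alone.

In a functional assay on the whole organism with Rattus norvegicus as the target (on this read-out higher numbers stand for an effect only at larger amounts of compound and lower numbers for an effect already at smaller amounts), compound 1 `CCOC(=O)C(=O)Nc1cccc(N(C)C)c1C#N` gives 4.2 mg/kg, compound 2 `CCOC(=O)C(=O)Nc1cccc(NC)c1C#N` gives 0.1 mg/kg and compound 3 `CCOC(=O)C(=O)Nc1cccc(N(C)CC)c1C#N` gives 0.5 mg/kg. Compound 3 thus stands in the middle of the three. Compound 4 `CCOC(=O)C(=O)Nc1cccc(C(=O)OC)c1C#N` carries methoxycarbonyl in place of ethyl(methyl)amino on an aromatic carbon. Small edits on that nitrogen already moved the numbers beyond the scatter, with a 42-fold lower number from compound 1 to compound 2 (1.62 log units; beyond the scatter) as a large step, and an 8.4-fold lower number from compound 1 to compound 3 (0.92 log units; beyond the scatter) and a 5.0-fold higher number from compound 2 to compound 3 (0.70 log units; beyond the scatter) as modest ones. Among the measured compounds shown here, no measured step removes the nitrogen altogether, so the direction is uncertain and any forecast must stay loose. A modest step upward is expected, written as a 2.0-fold higher number from compound 3 to compound 4 (0.30 log units; within the scatter). For compound 4 the estimated value is 1 mg/kg, with an expected range from 0.15 mg/kg to 6.5 mg/kg.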

Compound 4, dose for half-maximal effect: 0.8 mg/kg
Compound 4: the middle estimate sits 1.3-fold (0.10 log units) above what was measured; the range from low to high includes it.
By their numbers in this assay, from the lowest: compound 2; then compounds 3 and 4 (each within the scatter of the next); then compound 1.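

At this position a group without nitrogen can still work: putting methoxycarbonyl in place of ethyl(methyl)amino gives a 1.6-fold higher number from compound 3 to compound 4 (0.20 log units; within the scatter) in this assay. Measured against the other two amines, the change gives an 8.0-fold higher number from compound 2 to compound 4 (0.90 log units; beyond the scatter) and a 5.3-fold lower number from compound 1 to compound 4 (0.72 log units; beyond the scatter), so the outcome depends on which amine is replaced. No measured evidence explains these differences. From the compounds shown here alone, it remains open whether an unsubstituted amine, a carboxylic acid or a longer ester at this position would approach compound 2 or fall towards compound 1.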